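The source may report more compounds than this note shows. Statements on the series, on what has been measured and on what is new or still open speak of the compounds shown alone.

Measured so far:
compound 1, `COc1ccccc1C(=O)Nc1cccc(-c2oc3cc(-c4ccc(F)cc4)ccc3c(=O)c2O)c1`, in a functional assay on MDA-MB-231 cells (Homo sapiens) for antiproliferative activity, read by CCK-8 assay, with a stated time of 72 h (a higher number here means a weaker inhibitor, a lower number a stronger inhibitor), gives 5110 nM;
compound 2, `COc1cccc(C(=O)Nc2cccc(-c3oc4cc(-c5ccc(F)cc5)ccc4c(=O)c3O)c2)c1`, in this assay gives 9160 nM.

Compound 2 sits beside compound 1 on these numbers: the step of a 1.8-fold higher number from compound 1 to compound 2 (0.25 log units; within the scatter) is within the scatter, so the two cannot be told apart. Compound 3 `O=C(Nc1cccc(-c2oc3cc(-c4ccc(F)cc4)ccc3c(=O)c2O)c1)c1cccc(F)c1` differs from compound 2 by fluoro in place of methoxy on an aromatic carbon. Among the compounds with values here, no measured step swaps a methoxy for a fluoro; the only step in hand, 3-methoxyphenyl in place of 2-methoxyphenyl, stayed within the scatter, so in this assay no step beyond the scatter is expected. Compound 3 is estimated at 8000 nM, between 3000 nM and 25000 nM. This means an expected step of a 1.1-fold lower number from compound 2 to compound 3 (0.06 log units; within the scatter).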

Compound 3, half-maximal inhibitory concentration: 2510 nM
For compound 3 the middle estimate is 3.2-fold (0.50 log units) above the measured one; the whole stated range lies above it.
By their numbers in this assay, from the lowest: compound 3; then compounds 1 and 2 (each within the scatter of the next).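

Fluoro in place of methoxy on this aromatic carbon gives a 3.6-fold lower number from compound 2 to compound 3 (0.56 log units; beyond the scatter), the first step in this assay to pass the scatter, so the group held here does affect the reading. The step of a 2.0-fold lower number from compound 1 to compound 3 (0.31 log units; beyond the scatter) also passes the scatter, but it changes both the group and where it sits on the ring. Nothing measured here gives a cause for either step.

On these data alone, whether an amine or a carboxylic acid at this place would read like fluoro or like methoxy stays open. Also open, as far as these compounds go, is how fluoro would read where compound 1 carries its methoxy.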